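Para-substituent series on the shared core: cyclohexyl step

The source may report more compounds than this note shows. Statements on the series, on what has been measured and on what is new or still open speak of the compounds shown alone.

Measured so far:
compound 1 `c1ccc(N/N=C(\N=N\c2nnnn2-c2ccccc2)c2ccccc2)cc1` — 10000 nM
compound 2 `CCc1ccc(N/N=C(\N=N\c2nnnn2-c2ccccc2)c2ccccc2)cc1` — 3800 nM

Compound 1 gives the highest of the two numbers in an assay on lung for inhibition of Endothelin-converting enzyme 1 (Rattus norvegicus); on this read-out higher numbers stand for weaker inhibition and lower numbers for stronger inhibition. Its nearest neighbour is compound 2, which carries an ethyl group where compound 1 carries a hydrogen; that step, a 2.6-fold lower number from compound 1 to compound 2 (0.42 log units; beyond the scatter), is modest but beyond the scatter.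

Compound 3 `c1ccc(C(=N/Nc2ccc(C3CCCCC3)cc2)/N=N/c2nnnn2-c2ccccc2)cc1` is not yet measured in this assay. Relative to compound 1 the change is cyclohexyl in place of hydrogen on an aromatic carbon. Among the measured compounds shown here, the only measured step that bears on it is the one from compound 1 to compound 2, where a small alkyl group in the same position lowered the number beyond the scatter. Cyclohexyl is a larger carbon-only group entering at that same carbon, so a step of at least the same direction is the working expectation, with the size uncertain; a change of the kind seen for compound 2 is taken as the anchor, and a somewhat larger lowering is not excluded.

On that basis compound 3 is expected to give about 2500 nM in this assay, within 800 nM to 8000 nM, which corresponds to an estimated step of a 4.0-fold lower number from compound 1 to compound 3 (0.60 log units; beyond the scatter).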

Compound 3, half-maximal inhibitory concentration: 3600 nM
For compound 3 the middle estimate is 1.4-fold (0.16 log units) below the measured one; the measured number falls inside the stated range.
By their numbers in this assay, from the lowest: compounds 3 and 2 (each within the scatter of the next); then compound 1.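

In this assay, cyclohexyl in place of hydrogen on this aromatic carbon gives a 2.8-fold lower number from compound 1 to compound 3 (0.44 log units; beyond the scatter), so the lowering of the number is no longer tied to ethyl alone: two different carbon-only groups at this place on the shared core now both stand beyond the scatter from the unsubstituted compound 1. Replacing ethyl with cyclohexyl gives a 1.1-fold lower number from compound 2 to compound 3 (0.02 log units; within the scatter), so compound 2 and compound 3 cannot be told apart on this read-out, even though cyclohexyl brings in a six-membered non-aromatic ring of carbon only. No supporting data are available that would account for these two groups reading alike.

The compounds shown carry only hydrogen or carbon-only groups at this position, so it remains open whether an amine, a carboxylic acid or a methoxy group would fit the same picture. Going by these compounds, it also remains open whether a longer chain such as n-hexyl, or an aromatic group such as phenyl, would read with compound 2 and compound 3 or apart from them.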